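A 2,3-Dichlorophenyl Exchange in a Small Series

A few compounds are considered here, and "the series" means these few. Any claim that something is new, unique, unknown or untested is made for them only; others in the source may bear on it.

Of the compounds shown here, three with a shared core have been measured in a functional assay on HT-1080 cells (Homo sapiens) for cytotoxicity, read by MTT assay, with a stated time of 72 h; a lower number here means a stronger inhibitor, a higher number a weaker inhibitor. Compound 1 `COc1cccc(/C=C2\CCC/C(=C\c3cccc(OC)c3OC)C2=O)c1` gives 9900 nM, compound 2 `COc1ccc(/C=C2\CCC/C(=C\c3cccc(OC)c3OC)C2=O)cc1` gives 16300 nM and compound 3 `COc1cccc(/C=C2\CCC/C(=C\c3cccc(O)c3)C2=O)c1OC` gives 8500 nM. Compound 3 therefore stands within the scatter of both others, with a 1.2-fold lower number from compound 1 to compound 3 (0.07 log units; within the scatter) and a 1.9-fold lower number from compound 2 to compound 3 (0.28 log units; within the scatter).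

Compound 4 `COc1cccc(/C=C2\CCC/C(=C\c3cccc(Cl)c3Cl)C2=O)c1OC` carries 2,3-dichlorophenyl in place of 3-hydroxyphenyl on a double-bonded chain carbon bound to a double-bonded ring carbon. Two measured exchanges at this same place bear on it, and neither leaves the scatter: a 1.6-fold higher number from compound 1 to compound 2 (0.22 log units; within the scatter) and a 1.9-fold lower number from compound 2 to compound 3 (0.28 log units; within the scatter). The loss of a methyl on an oxygen, seen in a 1.2-fold lower number from compound 1 to compound 3 (0.07 log units; within the scatter), also stays within it. Going by the values given here, no measured compound carries chlorine, so this evidence is only indirect. On these small steps, no change beyond the scatter is expected in this assay, though with a wide margin. The expected change is a 1.1-fold higher number from compound 3 to compound 4 (0.02 log units; within the scatter). Compound 4 is estimated at 9000 nM, within an expected range of 3500 nM to 22000 nM.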

Compound 4, half-maximal inhibitory concentration: 19300 nM
Beside the measured number, compound 4's estimate is 2.1-fold (0.33 log units) below it; the measured number falls inside the stated range.
By their numbers in this assay, from the lowest: compounds 3, 1, 2 and 4 (each within the scatter of the next, the first and the last beyond it).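

Going by these compounds alone, at this position, in this assay, 2,3-dichlorophenyl in place of 3-hydroxyphenyl gives the first step to go beyond the scatter, though a modest one (a 2.3-fold higher number from compound 3 to compound 4 (0.36 log units; beyond the scatter)). Set against the two methoxyphenyl groups, the same 2,3-dichlorophenyl group stays within the scatter (a 1.2-fold higher number from compound 2 to compound 4 (0.07 log units; within the scatter); a 1.9-fold higher number from compound 1 to compound 4 (0.29 log units; within the scatter)), so among the groups shown at this place the change reads only against 3-hydroxyphenyl. Nothing measured on these compounds offers an account of this step.

The compounds shown leave open whether the step belongs to the arrival of the two chlorines or to the departure of 3-hydroxyphenyl. A 3-chlorophenyl group or a 3-aminophenyl group at this same place would help to separate the two readings.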